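A few compounds are considered here, and "the series" means these few. Any claim that something is new, unique, unknown or untested is made for them only; others in the source may bear on it.

Working notes on the series.

Compound 2 `Oc1ccccc1/C=N/c1sc2c(c1-c1nc3ccccc3s1)CCCC2` and compound 1 `C(=C/c1ccccc1)\C=N\c1sc2c(c1-c1nc3ccccc3s1)CCCC2` share one core; in an ADME assay on HepG2 cells (Homo sapiens) for cytotoxicity, read by MTT assay, with a stated time of 72 h (on this read-out lower numbers stand for higher toxicity in this test and higher numbers for lower toxicity in this test), compound 2 gives 114 ug/mL, and compound 1 gives 467 ug/mL. The change between them is 2-phenylethenyl in place of 2-hydroxyphenyl on a carbon with a double bond to nitrogen and it made the step of a 4.1-fold higher number from compound 2 to compound 1 (0.61 log units; beyond the scatter).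

Compound 3 `Oc1ccccc1/C=N/c1sc2c(c1-c1nc3cc(Cl)ccc3s1)CCC2` sits on a second core; the difference between the two cores is not broken down here. In this assay compound 3 gives 210 ug/mL. Against compound 2 this is within the scatter, so the two values are not told apart; against compound 1 the gap is beyond the scatter.

Compound 4 `Clc1ccc2sc(-c3c(/N=C/C=C/c4ccccc4)sc4c3CCC4)nc2c1` is not yet measured. It differs from compound 3 by 2-phenylethenyl in place of 2-hydroxyphenyl on a carbon with a double bond to nitrogen, the same change, at the same place, as that from compound 2 to compound 1. For the measured compounds named here, on the second core a step of like size is expected, resting on the measured step of a 4.1-fold higher number from compound 2 to compound 1 (0.61 log units; beyond the scatter) on the first core; there is only that one example, so the expectation is loose. The step from compound 3 to compound 4 is estimated at a 3.6-fold higher number from compound 3 to compound 4 (0.55 log units; beyond the scatter), and compound 4 is expected to give 750 ug/mL in this assay, between 350 ug/mL and 1500 ug/mL.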

Compound 4, half-maximal cytotoxic concentration: 14.9 ug/mL
The estimate for compound 4 lay 50-fold (1.70 log units) above the measured number; the measured number lies below the stated range.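

In this assay, the change to 2-phenylethenyl in place of 2-hydroxyphenyl on a carbon with a double bond to nitrogen gives, on the second core, a 14-fold lower number from compound 3 to compound 4 (1.15 log units; beyond the scatter). The effect of this change therefore does not carry from one core to the other in this series, and its direction reverses: the same change on two cores in this assay, a 4.1-fold higher number (0.61 log units; beyond the scatter) from compound 2 to compound 1 and a 14-fold lower number (1.15 log units; beyond the scatter) from compound 3 to compound 4, 58-fold (1.76 log units) apart, beyond the scatter of two such steps. This shows that a step measured on one core cannot be used to estimate the same step on the other, but with a single pair on each core it does not show which difference between the cores goes with the reversal, nor how the change behaves on any further core.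

The compounds shown leave open whether the reversal follows the chlorine on the core or the other difference between the two cores. They also leave open whether a different group on the same carbon, such as an unsubstituted phenyl or a simple amine-bearing chain, would follow the first core's direction or the second's.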